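The compounds below may be only part of what the source reports. "The series", "measured", "known", "first", "only" and "open" are said of these compounds alone.

Measured so far:
- compound 1, `O=C(O)CCCC/C=C(/c1ccc(F)cc1)c1cccnc1`, in an assay (Equus caballus) for inhibition of Thromboxane-A synthase (Homo sapiens), using microsomes (on this read-out lower numbers stand for stronger inhibition and higher numbers for weaker inhibition), compound 1 gives 83 nM
- compound 2, `C/C(=C/CCCCC(=O)O)c1cccnc1`, in this assay compound 2 gives 71 nM

Compound 2 has the lower of the two numbers, yet the step of a 1.2-fold lower number from compound 1 to compound 2 (0.07 log units; within the scatter) stays within the scatter, so the two compounds cannot be told apart. Compound 3, `O=C(O)CCCC/C=C(\c1cccnc1)c1cccs1`, is not yet measured. It carries thiophen-2-yl in place of methyl on a double-bonded chain carbon bound to an aromatic carbon and a double-bonded chain carbon. Among the compounds with values here, only one measured step bears on this: swapping a ring for the methyl at that place changed little, as seen from compound 1 to compound 2. The expected step of a 1.1-fold higher number from compound 2 to compound 3 (0.02 log units; within the scatter) is therefore small, not beyond the scatter. Compound 3 is estimated at 75 nM, within 30 nM to 200 nM.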

Compound 3, half-maximal inhibitory concentration: 20 nM
Compound 3: the middle estimate sits 3.8-fold (0.57 log units) above what was measured; the whole stated range lies above it.
By their numbers in this assay, from the lowest: compound 3; then compounds 2 and 1 (each within the scatter of the next).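

In this assay this place turns out to respond to the group it carries: the number falls with thiophen-2-yl in place of methyl (a 3.6-fold lower number from compound 2 to compound 3 (0.55 log units; beyond the scatter)) and in place of 4-fluorophenyl (a 4.2-fold lower number from compound 1 to compound 3 (0.62 log units; beyond the scatter)). Having a ring there is not enough on its own, since 4-fluorophenyl and methyl stay within the scatter of each other. No measurement at hand explains why thiophen-2-yl stands apart. Still open, going by these compounds, is whether the lower number goes with the sulfur or with the five-membered ring. Furan-2-yl or plain phenyl at this place would help separate the two.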